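Bromo for acetyl on a vasorelaxant chromene-type core

The compounds below may be only part of what the source reports. "The series", "measured", "known", "first", "only" and "open" are said of these compounds alone.

Compound 1 `CC(=O)c1ccc2c(c1)C(n1ccccc1=O)=CC(C)(C)O2`: 7.37
Compound 2 `CC1(C)C=C(n2ccccc2=O)c2cc(OC(=O)Nc3ccc(F)cc3)ccc2O1`: 5.3

Of the compounds shown here, two have been measured in a functional assay (aorta) with Rattus norvegicus as the target; on this read-out lower numbers stand for lower potency and higher numbers for higher potency (the scale is a negative logarithm). Compound 1 gives 7.37 and is the higher of the two numbers. Compound 2 gives 5.3, a figure that lies well beyond the scatter below compound 1. Within the data shown here, the two differ in more than one place, so their gap cannot be tied to a single change; it shows only that compound 1 is the stronger of the pair in this assay.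

Compound 3 `CC1(C)C=C(n2ccccc2=O)c2cc(Br)ccc2O1` has not yet been measured. It differs from compound 1 by bromo in place of acetyl on an aromatic carbon

Among the measured compounds shown here, no single-change step between measured compounds is available to calibrate this replacement. Both compound 1 and compound 3 keep the shared core unchanged and carry a small group on the same aromatic carbon; the acetyl is exchanged for a bromo. Compound 3 is therefore expected to retain a good part of the potency of compound 1, with a modest downward step a number 0.57 log units lower from compound 1 to compound 3 (beyond the scatter) that may or may not exceed the scatter. The estimate for compound 3 in this assay is 6.8, within a range of 6 to 7.6.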

Compound 3, logarithm of the reciprocal of the active concentration, log(1/C): 7.84
Compound 3: the middle estimate sits 1.04 log units below what was measured, outside the stated range (above it).
By their numbers in this assay, from the lowest: compound 2; then compound 1; then compound 3.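

Among these compounds, exchanging acetyl for bromo on this aromatic carbon gives, in this assay, a number 0.47 log units higher from compound 1 to compound 3 (beyond the scatter) and is the first one-place comparison. The acetyl is therefore not needed for high potency at this position: the single bromine atom takes the place of its three heavy atoms, and the double bond and hydrogen-bond acceptor counted for the acetyl go with it, yet the number rises rather than falls. The data offer no measurement that accounts for the direction or size of this step.

This single pair cannot show whether the gain belongs to bromo in particular or would extend to other replacements on the same carbon, such as a chloro or iodo atom, a nitrile, an amine, a carboxylic acid or a longer acyl chain like propanoyl. It also leaves open whether bromo would keep its edge over acetyl if the pyridone-type ring or the two methyl groups of the shared core were changed, and whether the same order would hold in any read-out other than this assay.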